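Triazole Aryl Swap on a Spiro Core: Compound 4 Expected

A few compounds are considered here, and "the series" means these few. Any claim that something is new, unique, unknown or untested is made for them only; others in the source may bear on it.

Compound 1 `Cc1cccc(-n2nncc2CN2C(=O)C3(C(C#N)=C(N)Oc4c(N)cc5nc6ccccc6nc5c43)c3ccccc32)c1`: 12300 nM
Compound 2 `N#CC1=C(N)Oc2c(N)cc3nc4ccccc4nc3c2C12C(=O)N(Cc1cnnn1-c1ccc([N+](=O)[O-])cc1)c1ccccc12`: the limit > 50000 nM
Compound 3 `COc1ccc(OC)c(-n2nncc2CN2C(=O)C3(C(C#N)=C(N)Oc4c(N)cc5nc6ccccc6nc5c43)c3ccccc32)c1`: 28100 nM

In a functional assay on A549 cells (Homo sapiens) for antiproliferative activity, read by MTT assay, with a stated time of 48 h (on this read-out lower numbers stand for stronger inhibition and higher numbers for weaker inhibition), compound 1 gives 12300 nM. Compound 2 reaches only a limit of the assay, > 50000 nM, which is the limit of > 50000 nM in this assay, at which 1 of the 3 values shown sits. Compound 3 gives 28100 nM and so carries the highest of the two numbers shown; its nearest neighbour is compound 1, separated by a 2.3-fold higher number from compound 1 to compound 3 (0.36 log units; beyond the scatter). Toward the limit of compound 2 the move is an at least 1.7-fold lower number from compound 2 to compound 3 (0.25 log units; that floor lies within the scatter).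

Compound 4 `Cc1ccc(-n2nncc2CN2C(=O)C3(C(C#N)=C(N)Oc4c(N)cc5nc6ccccc6nc5c43)c3ccccc32)cc1Cl` differs from compound 3 by 3-chloro-4-methylphenyl in place of 2,5-dimethoxyphenyl on an aromatic nitrogen. The swaps already measured at this aromatic nitrogen, a 2.3-fold higher number from compound 1 to compound 3 (0.36 log units; beyond the scatter) and an at least 4.0-fold higher number from compound 1 to compound 2 (0.60 log units; beyond the scatter), both start from the 3-methylphenyl of compound 1, which holds the lowest number. Since 3-chloro-4-methylphenyl keeps a methyl-bearing phenyl like that of compound 1, compound 4 is expected to sit nearer compound 1 than compound 3, a step of a 1.9-fold lower number from compound 3 to compound 4 (0.27 log units; within the scatter) that may still fall within the scatter. Compound 4 is estimated at 15000 nM, within a range from 6000 nM to 40000 nM.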

Compound 4, half-maximal inhibitory concentration: 11800 nM
For compound 4 the middle estimate is 1.3-fold (0.10 log units) above the measured one; measured number inside the range.
By their numbers in this assay, from the lowest: compounds 4 and 1 (each within the scatter of the next); then compound 3. At a limit, above all of these: compound 2.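

In this assay, 3-chloro-4-methylphenyl on the aromatic nitrogen cannot be told apart from the 3-methylphenyl of compound 1: a 1.0-fold lower number from compound 1 to compound 4 (0.02 log units; within the scatter). A second substituted phenyl bearing a methyl group therefore shares the low end of this small series, and it separates from the two phenyl groups without methyl, with a 2.4-fold lower number from compound 3 to compound 4 (0.38 log units; beyond the scatter) and an at least 4.2-fold lower number from compound 2 to compound 4 (0.62 log units; beyond the scatter). The second of these steps is only a bound, as compound 2 stands at a limit and not at a number: the limit of > 50000 nM in this assay, at which 1 of the 4 values shown sits.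

As far as these compounds go, whether the methyl alone holds the number remains open, and a phenyl carrying only a methyl, only a chlorine or nothing at all would separate the two substituents. Also open, from the compounds shown here alone, is whether the aromatic ring is needed at this nitrogen, which a benzyl or a cyclohexyl group would test.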